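Isobutyl to cyclohexylmethyl: one measured step to go on

The source may report more compounds than this note shows. Statements on the series, on what has been measured and on what is new or still open speak of the compounds shown alone.

In an ADME assay on microsomes from liver (Mus musculus, strain CD1) for metabolic stability, read by HPLC, with a stated time of 30 min, tested at 1 uM (a higher number here means faster removal of the compound, a lower number slower removal), compound 1 (`O=S(=O)(Nc1c(C2CCCCC2)ccc2ncccc12)c1ccc(Br)cc1`) gives 38 mL.min-1.g-1 as a measured number. Compound 2 (`CC(C)Cc1ccc2ncccc2c1NS(=O)(=O)c1ccc(Br)cc1`) gives > 50 mL.min-1.g-1 in this assay and this is a limit of the assay, not a number.

Compound 3 (`O=S(=O)(Nc1c(CC2CCCCC2)ccc2ncccc12)c1ccc(Br)cc1`) is built from compound 2 through one change, (cyclohexyl in place of isopropyl on a saturated chain carbon bound to an aromatic carbon), with cyclohexyl in place of isopropyl on a saturated chain carbon bound to an aromatic carbon. The same change can be read as isobutyl to cyclohexylmethyl.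

Among the measured compounds shown here, only one measured step bears on this, an at least 1.3-fold higher number from compound 1 to compound 2 (0.11 log units; that floor lies within the scatter), with isobutyl in place of cyclohexyl on an aromatic carbon. As far as these compounds go, it is a weak guide, as it stands at a different place and its true size is unknown. Compound 3 carries cyclohexyl again, as does compound 1 at 38 mL.min-1.g-1, and a value in that region is expected. The expected step is an at least 1.1-fold lower number from compound 2 to compound 3 (0.07 log units; that floor lies within the scatter), which is no firm move beyond the scatter. For compound 3 the estimated value in this assay is 42 mL.min-1.g-1, with an expected range from 20 mL.min-1.g-1 to 75 mL.min-1.g-1.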

Compound 3, intrinsic clearance in microsomes: 33 mL.min-1.g-1
The estimate for compound 3 lay 1.3-fold (0.10 log units) above the measured number; the range from low to high includes it.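

Compound 2 gives > 50 mL.min-1.g-1 in this assay and this is a limit of the assay, not a number. Cyclohexyl in place of isopropyl on a saturated chain carbon bound to an aromatic carbon gives an at least 1.5-fold lower number from compound 2 to compound 3 (0.18 log units; that floor lies within the scatter) and this can be read only as a floor on the step, because the true number for compound 2 lies out of reach of the assay: the limit of > 50 mL.min-1.g-1 in this assay, at which 1 of the 3 values shown sits.

The step from the cyclohexyl group to the cyclohexylmethyl group is a 1.2-fold lower number from compound 1 to compound 3 (0.06 log units; within the scatter) so, with measured numbers on both sides, this pair shows that the two groups cannot be told apart in this assay whereas the isobutyl group of compound 2 leaves only a limit.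

As far as these compounds go, how far compound 2 truly stands from compound 3 stays open, since a floor within the scatter does not establish a real difference. Also open is whether a longer chain ending in cyclohexyl, or an amine or a carboxylic acid at this place, would move the number in this assay beyond the scatter, since the groups shown here are all made of carbon only.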